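Swapping the Acid Head: Paw Edema Inhibition Holds Steady

The compounds below may be only part of what the source reports. "The series", "measured", "known", "first", "only" and "open" are said of these compounds alone.

The measured compounds, all read in a functional assay on the whole organism (strain Wistar) for inhibition, with Rattus norvegicus as the target, read by paw edema, with stated times of 60 min and 1 h, at a dose of 100 mg/kg by the oral route; a higher number here means more inhibition at the dose given (going by the name of the read-out), a lower number less inhibition:

compound 1 `COc1cc2c(cc1OC)C(CC(=O)O)CC2` gives 18.8%
compound 2 `COc1cc2c(cc1OC)C(CC(=O)NCc1ccccc1)CC2` gives 18.8%
compound 3 `COc1cc2c(cc1OC)C(CC(=O)N1CCCCC1)CC2` gives 18.8%

On these numbers compound 1 stands level with compounds 2 and 3. The step of no change at the digits printed from compound 1 to compound 2 (within the scatter) and the step of no change at the digits printed from compound 1 to compound 3 (within the scatter) both show that replacing the hydroxy on the carbonyl carbon with a benzylamino or a piperidin-1-yl group leaves the reading where it was, and the step of no change at the digits printed from compound 2 to compound 3 (within the scatter) confirms that the two amides themselves do not part company.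

Compound 4 `COc1cc2c(cc1OC)C(CC(=O)N1CCNCC1)CC2` is the next variation at the same position. Compared with compound 1 the change is piperazin-1-yl in place of hydroxy on a carbonyl carbon. Among the compounds with values here, the steps that bear on it are those from compound 1 to its two amides, above all the step to the piperidin-1-yl compound 3, since that ring differs from the incoming one only in the second ring atom; each of those steps was flat within the scatter. The account therefore expects no step beyond the scatter in this assay for compound 4, with no change at the digits printed from compound 1 to compound 4 (within the scatter) as the expected change. Compound 4 is estimated at 18.8%, within a range from 8% to 30%.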

Compound 4, a percentage reported as inhibition, in the whole organism at one dose (the size of the read-out at that dose, not a potency): 62.5%
The estimate for compound 4 lay 43.7 percentage points below the measured number, and the stated range ends below it.
By their numbers in this assay, from the lowest: compounds 1, 2 and 3 (each within the scatter of the next); then compound 4.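

In this assay, this position on the carbonyl carbon proves not to be indifferent to the group it carries, as piperazin-1-yl in place of hydroxy gives a number 43.7 percentage points higher from compound 1 to compound 4 (beyond the scatter). Within the data shown here, the flat readings among the earlier compounds therefore do not hold for every amide: piperazin-1-yl in place of piperidin-1-yl gives a number 43.7 percentage points higher from compound 3 to compound 4 (beyond the scatter), and piperazin-1-yl in place of benzylamino gives a number 43.7 percentage points higher from compound 2 to compound 4 (beyond the scatter), so the change that matters here is the one between amide groups, not the one from the acid to an amide as such. No measurement at hand bears on what lies behind this separation of compound 4 from the other three.

The compounds shown leave open whether the second ring nitrogen of the piperazin-1-yl group is what counts, a question that a morpholin-4-yl amide, with oxygen at that ring place, or a piperazin-1-yl ring carrying a methyl group on that nitrogen could address. Going by these compounds, with every reading taken at a single oral dose, how the inhibition of compound 4 varies with dose also remains open.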